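The source may report more compounds than this note shows. Statements on the series, on what has been measured and on what is new or still open speak of the compounds shown alone.

Measured so far, in a functional assay on CHO-K1 cells with Glucose-dependent insulinotropic receptor (Homo sapiens) as the target, read by a luciferase reporter, with a stated time of 5 h; a higher number here means a larger maximal response, a lower number a smaller maximal response: compound 1 `COC(=O)N1CCC(Oc2ncnc3c2CCN3c2ccc(S(C)(=O)=O)cc2F)CC1` gives 119%, compound 2 `CCOC(=O)N1CCC(Oc2ncnc3c2CCN3c2ccc(S(C)(=O)=O)cc2F)CC1` gives 135%, and compound 3 `CCSC(=O)N1CCC(Oc2ncnc3c2CCN3c2ccc(S(C)(=O)=O)cc2F)CC1` gives 128%.

Between compound 1 and compound 2 the change is methyl in place of hydrogen on a saturated chain carbon bound to an oxygen next to a carbonyl group, and it made the step of a number 16 percentage points higher from compound 1 to compound 2 (beyond the scatter). The change from compound 1 to compound 3 is ethylsulfanyl in place of methoxy on a carbonyl carbon; the step of a number 9 percentage points higher from compound 1 to compound 3 (within the scatter) and the step of a number 7 percentage points lower from compound 2 to compound 3 (within the scatter) both stay within the scatter.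

Compound 4 `CC(C)SC(=O)N1CCC(Oc2ncnc3c2CCN3c2ccc(S(C)(=O)=O)cc2F)CC1` is not yet measured. It differs from compound 3 by methyl in place of hydrogen on a saturated chain carbon bound to a saturated chain carbon and a sulfur. This is the same kind of change as from compound 1 to compound 2, but the place differs: there the carbon was bound to an oxygen next to a carbonyl group, here it is bound to a saturated chain carbon and a sulfur. Resting on the step of a number 16 percentage points higher from compound 1 to compound 2 (beyond the scatter), a step of a number 8 percentage points higher from compound 3 to compound 4 (within the scatter) is expected for compound 4 in this assay. Compound 4 is estimated at 136%, between 118% and 154%.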

Compound 4, largest response reached (reported as percent of maximum), in percent of the reference or control that the assay uses: 138%
Compound 4: middle estimate off by 2 percentage points, on the low side; low and high end bracket the measured number.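

In this assay, methyl in place of hydrogen on the sulfur-bound chain gives a number 10 percentage points higher from compound 3 to compound 4 (within the scatter), and this step can be set beside the earlier one: the same change on two cores in this assay, a number 16 percentage points higher (beyond the scatter) from compound 1 to compound 2 and a number 10 percentage points higher (within the scatter) from compound 3 to compound 4, 6 percentage points apart, within the scatter of two such steps

The change therefore carries from one core to the other with no detectable difference in size, but two pairs establish no general rule, and the step on the sulfur side does not by itself stand clear of the scatter. Isopropylsulfanyl in place of ethoxy gives a number 3 percentage points higher from compound 2 to compound 4 (within the scatter), while in place of methoxy it gives a number 19 percentage points higher from compound 1 to compound 4 (beyond the scatter).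

The compounds shown leave open how a longer chain such as butyl, or a cyclopropyl ring, would behave on the oxygen or sulfur. An amine on the carbonyl carbon also remains an open case.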